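The source may report more compounds than this note shows. Statements on the series, on what has been measured and on what is new or still open speak of the compounds shown alone.

Compound 1 `CC(C)(C)c1ccc(CNCCCNS(=O)(=O)c2cc(C(F)(F)F)cc(C(F)(F)F)c2)cc1` gives 3200 nM in a toxicity assay on MCF-10A cells (Homo sapiens) for inhibition, read by MTT assay, with a stated time of 72 h; on this read-out higher numbers stand for weaker inhibition of growth and lower numbers for stronger inhibition of growth. Compound 2 `O=S(=O)(NCCCNCc1ccc(Cl)cc1)c1cc(C(F)(F)F)cc(C(F)(F)F)c1` gives 2300 nM.

Compound 1 has the highest of the two numbers; its nearest neighbour is compound 2, with a 1.4-fold lower number from compound 1 to compound 2 (0.14 log units; within the scatter). Compound 3 `COc1ccccc1CNCCCNS(=O)(=O)c1cc(C(F)(F)F)cc(C(F)(F)F)c1` has not been measured. The change from compound 1 is 2-methoxyphenyl in place of 4-(tert-butyl)phenyl on a saturated chain carbon bound to an amine nitrogen. Among the measured compounds shown here, the only measured step at this position, a 1.4-fold lower number from compound 1 to compound 2 (0.14 log units; within the scatter), stayed within the scatter, so no step beyond the scatter is expected here either. Compound 3 is therefore estimated at 3000 nM, with a range from 1200 nM to 8000 nM, which is expected to mean a 1.1-fold lower number from compound 1 to compound 3 (0.03 log units; within the scatter).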

Compound 3, concentration for 50% growth inhibition: 5500 nM
Compound 3: the middle estimate sits 1.8-fold (0.26 log units) below what was measured, within the range that was stated.
By their numbers in this assay, from the lowest: compounds 2, 1 and 3 (each within the scatter of the next, the first and the last beyond it).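

In this assay, among the compounds shown here, 2-methoxyphenyl in place of 4-chlorophenyl on a saturated chain carbon bound to an amine nitrogen gives the first step beyond the scatter at this position, though a modest one (a 2.4-fold higher number from compound 2 to compound 3 (0.38 log units; beyond the scatter)). Against 4-(tert-butyl)phenyl, the same group stays within the scatter (a 1.7-fold higher number from compound 1 to compound 3 (0.24 log units; within the scatter)), so the position has so far shown only a small response. No evidence here bears on this result. On these data alone, how a carboxylic acid or a dimethylamino group in place of these substituents would read remains open, as does whether any change here could produce a larger step.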